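The compounds below may be only part of what the source reports. "The series", "measured", "known", "first", "only" and "open" are said of these compounds alone.

Compound 2 `CC(C)(Oc1ccccc1)C1OCC(C/C=C\CCC(=O)O)C(c2cccnc2)O1` gives, in a functional assay for inhibition, with Homo sapiens as the target (a higher number here means weaker binding, a lower number tighter binding), a reading of 75.9 nM. Among the three compounds measured so far it holds the second highest number: compound 1 `O=C(O)CC/C=C\CC1COC(c2ccc([N+](=O)[O-])cc2)OC1c1cccnc1` gives 933 nM in this assay, and compound 3 `CSc1ccc(OC(C)(C)C2OCC(C/C=C\CCC(=O)O)C(c3cccnc3)O2)c([N+](=O)[O-])c1` gives 4.47 nM. One measured step brought a 12-fold lower number from compound 1 to compound 2 (1.09 log units; beyond the scatter), and the other brought a 17-fold lower number from compound 2 to compound 3 (1.23 log units; beyond the scatter); both are large.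

Compound 4 `CC(C)(Sc1ccccc1)C1OCC(C/C=C\CCC(=O)O)C(c2cccnc2)O1` has not been measured. It differs from compound 2 in one place: phenylsulfanyl in place of phenoxy on a saturated chain carbon bound to two saturated chain carbons and a saturated ring carbon. Neither measured step tests a swap of this kind. The step of a 12-fold lower number from compound 1 to compound 2 (1.09 log units; beyond the scatter) exchanged the whole group on a saturated ring carbon, and the step of a 17-fold lower number from compound 2 to compound 3 (1.23 log units; beyond the scatter) changed the six-membered aromatic ring of carbon only that sits on the oxygen, while that oxygen stayed in place. Going by the values given here, a sulfur taking the place of that oxygen, with the ring itself unchanged, has no counterpart among the measured compounds, so no step beyond the scatter is expected in this assay in either direction, and the reading of compound 2 is the best anchor available. The estimate for compound 4 in this assay is therefore 65 nM, expected to fall within 15 nM to 280 nM, which corresponds to an expected step of a 1.2-fold lower number from compound 2 to compound 4 (0.07 log units; within the scatter).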

Compound 4, dissociation constant: 200 nM
Beside the measured number, compound 4's estimate is 3.1-fold (0.49 log units) below it; the measured number falls inside the stated range.
By their numbers in this assay, from the lowest: compound 3; then compound 2; then compound 4; then compound 1.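

In this assay, phenylsulfanyl in place of phenoxy on a saturated chain carbon bound to two saturated chain carbons and a saturated ring carbon brings a 2.6-fold higher number from compound 2 to compound 4 (0.42 log units; beyond the scatter) even though the two groups have the same counts of heavy atoms, hydrogen-bond donors and hydrogen-bond acceptors, so this single atom change alone moves the number beyond the scatter. The larger exchange on the saturated ring carbon still pays off with sulfur in the new group, with a 4.7-fold lower number from compound 1 to compound 4 (0.67 log units; beyond the scatter) in place of the larger 12-fold lower number from compound 1 to compound 2 (1.09 log units; beyond the scatter) seen with oxygen, so phenoxy is the better of the two groups here, though phenylsulfanyl keeps part of the gain. No supporting measurement is available to explain why sulfur and oxygen differ at this position.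

As far as these compounds go, it remains open whether a methylene or an amine in place of the phenoxy oxygen would fall nearer compound 2 or compound 4. It is also open whether adding nitro and methylsulfanyl groups to the ring of phenylsulfanyl would help as much as the only ring change shown, a 17-fold lower number from compound 2 to compound 3 (1.23 log units; beyond the scatter) on phenoxy.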